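Pyridin-3-yl in Place of Thiophen-2-yl: Expected Cytotoxicity

A few compounds are considered here, and "the series" means these few. Any claim that something is new, unique, unknown or untested is made for them only; others in the source may bear on it.

Compound 1 `O=S(=O)(Cc1nc(-c2cccs2)c2sccc2n1)c1cccc(Cl)c1` was examined in an ADME assay on cells (Homo sapiens) for cytotoxicity, read by resazurin assay, with a stated time of 5 days; on this read-out higher numbers stand for lower toxicity in this test and lower numbers for higher toxicity in this test. In this assay compound 1 gives > 50000 nM, which is a limit of the test rather than a measured number. A second compound, compound 2 `COc1ccc(-c2nc(C(C)S(=O)(=O)c3cccc(Cl)c3)nc3ccsc23)cn1`, belongs to the same study. In this assay compound 2 gives > 50000 nM, again a limit and not a number. Compound 1 thus stands at the boundary of what the test can report, and the other value shown sits at that same boundary (the limit of > 50000 nM in this assay, at which 2 of the 2 values shown sit). Among the measured compounds shown here, no two of the measured compounds differ in just one place, so no measured step is available to guide the next change. The new compound, compound 3 `O=S(=O)(Cc1nc(-c2cccnc2)c2sccc2n1)c1cccc(Cl)c1`, differs from compound 1 in this way: pyridin-3-yl in place of thiophen-2-yl on an aromatic carbon. Because compound 1 rests at the limit of > 50000 nM in this assay, at which 2 of the 2 values shown sit, the step from compound 1 to compound 3 is expected to be none beyond the usual scatter, a step that the limit leaves unreadable from compound 1 to compound 3. For compound 3 the value in this assay is expected near 60000 nM, within 25000 nM to 150000 nM, and most probably reported only as a limit.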

Compound 3, half-maximal cytotoxic concentration: > 50000 nM
Compound 3 ended at the assay's limit; the forecaster's own chance of this, stated with the estimate: 75%; the middle value lies beyond the limit too.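

In this assay compound 3 gives > 50000 nM, a limit of the test and not a number. The step between compound 1 and compound 3 cannot be read, because both compounds rest at the same boundary: the limit of > 50000 nM in this assay, at which 3 of the 3 values shown sit.

The compounds shown leave open at what concentration any of them would become toxic to cells, and whether pyridin-3-yl in place of thiophen-2-yl changes that concentration at all.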